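Hydroxy to fluoro on the shared core: maximal response

The source may report more compounds than this note shows. Statements on the series, on what has been measured and on what is new or still open speak of the compounds shown alone.

Two compounds of the series have numbers in a functional assay on cells for agonist activity at Glucose-dependent insulinotropic receptor (Homo sapiens), read by a luciferase reporter, with a stated time of 4 h; on this read-out lower numbers stand for smaller maximal responses and higher numbers for larger maximal responses. Compound 1 `CC(=O)c1cnc(N2CCC(c3coc4c(N5CCc6cc(S(C)(=O)=O)ccc65)ncnc34)CC2)nc1` gives 12% in this assay, while compound 2 `CS(=O)(=O)c1ccc2c(c1)CCN2c1ncnc2c(C3CCN(c4ncc(O)cn4)CC3)coc12` gives 145%. Among the measured compounds shown here, compound 2 therefore stands highest of the two, with compound 1 as its only neighbour, and the single measured step, a number 133 percentage points higher from compound 1 to compound 2 (beyond the scatter), is the only one on record.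

Compound 3 `CS(=O)(=O)c1ccc2c(c1)CCN2c1ncnc2c(C3CCN(c4ncc(F)cn4)CC3)coc12` has not been measured. It differs from compound 2 by fluoro in place of hydroxy on an aromatic carbon, at the position on the six-membered aromatic ring with 2 nitrogen that also carried the change from compound 1 to compound 2. That step bears on the present one: it was large, and it shows that this position governs the maximal response strongly. Nothing measured tells how fluoro compares with hydroxy at this place, so a step back toward compound 1 is expected but its size is uncertain, estimated at a number 55 percentage points lower from compound 2 to compound 3 (beyond the scatter). For compound 3 a maximal response of 90% is expected in this assay, within 30% to 150%.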

Compound 3, largest response reached (Emax), in percent of the reference or control that the assay uses: 229%
Compound 3: the middle estimate sits 139 percentage points below what was measured; measured number outside the range, above it.
By their numbers in this assay, from the lowest: compound 1; then compound 2; then compound 3.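

In this assay, fluoro in place of hydroxy gives a number 84 percentage points higher from compound 2 to compound 3 (beyond the scatter) and so shows that hydroxy does not mark the top of the range at this position on the pyrimidine ring. Fluoro in place of acetyl gives a number 217 percentage points higher from compound 1 to compound 3 (beyond the scatter) and sets the order at this carbon, for these three compounds only, as acetyl, then hydroxy, then fluoro; the change spans a wider range of maximal response than the earlier pair showed. Since fluoro counts no hydrogen-bond donor, a donor at this carbon is not required for a large maximal response in this pair, and nothing on hand accounts for the order of the three groups.

The compounds shown leave open how chloro, methoxy, an amine or a nitrile on this carbon would stand against fluoro. They also leave open whether the order of acetyl, hydroxy and fluoro would hold on a different core or on a read-out other than maximal response.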